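Chalcone dithiocarbamates against an oesophageal carcinoma line

A few compounds are considered here, and "the series" means these few. Any claim that something is new, unique, unknown or untested is made for them only; others in the source may bear on it.

Compound 1 `O=C(/C=C/c1ccc(Cl)cc1)c1ccc(OCCCSC(=S)N2CCCC2)cc1`: 18600 nM
Compound 2 `CN1CCN(C(=S)SCCCOc2ccc(C(=O)/C=C/c3ccc(Cl)cc3)cc2)CC1`: 34200 nM
Compound 3 `COc1cc(/C=C/C(=O)c2ccc(OCCCSC(=S)N3CCN(C)CC3)cc2)cc(OC)c1OC`: 7430 nM

Three compounds were tested in a functional assay on ECa-109 cells for inhibition, with ECa-109 cell line (Homo sapiens) as the target, read by MTT assay, with a stated time of 72 h; on this read-out lower numbers stand for stronger inhibition and higher numbers for weaker inhibition. Compound 2 gives 34200 nM in this assay, and compound 1, which carries pyrrolidin-1-yl in place of 4-methylpiperazin-1-yl on a thiocarbonyl carbon, gives 18600 nM; the step of a 1.8-fold lower number from compound 2 to compound 1 (0.26 log units; within the scatter) stays within the scatter. Compound 3 carries 3,4,5-trimethoxyphenyl in place of 4-chlorophenyl on a double-bonded chain carbon bound to a double-bonded chain carbon and gives 7430 nM, so that a 4.6-fold lower number from compound 2 to compound 3 (0.66 log units; beyond the scatter). Compound 3 has the lowest number of the three, and its steps to compound 1 and to compound 2 both lie beyond the scatter.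

Compound 4 `COc1cc(/C=C/C(=O)c2ccc(OCCCSC(=S)N3CCCC3)cc2)cc(OC)c1OC` is not yet measured. It differs from compound 3 by pyrrolidin-1-yl in place of 4-methylpiperazin-1-yl on a thiocarbonyl carbon, the same change as from compound 2 to compound 1, where it made a 1.8-fold lower number from compound 2 to compound 1 (0.26 log units; within the scatter). On that earlier step alone, compound 4 is expected to show a 1.7-fold lower number from compound 3 to compound 4 (0.22 log units; within the scatter), a step that stays within the scatter. The estimate for compound 4 in this assay is 4500 nM, with a range from 1800 nM to 11000 nM.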

Compound 4, half-maximal inhibitory concentration: 11100 nM
The estimate for compound 4 lay 2.5-fold (0.39 log units) below the measured number; the measured number lies above the stated range.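

In this assay, pyrrolidin-1-yl in place of 4-methylpiperazin-1-yl on the thiocarbonyl carbon of compound 3 gives a step that stays within the scatter (a 1.5-fold higher number from compound 3 to compound 4 (0.17 log units; within the scatter)). The same change also stays within the scatter on the core of compound 2, yet the two steps run in opposite directions and do not agree: the same change on two cores in this assay, a 1.8-fold lower number (0.26 log units; within the scatter) from compound 2 to compound 1 and a 1.5-fold higher number (0.17 log units; within the scatter) from compound 3 to compound 4, 2.7-fold (0.44 log units) apart, beyond the scatter of two such steps

The change therefore does not carry from one core to the other as a fixed shift, although two pairs cannot show what sets the difference or how it would run on any further core.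

As far as these compounds go, it remains open how morpholin-4-yl or diethylamino on the thiocarbonyl carbon would compare on these two cores. From the compounds shown here alone, a longer chain on the ether oxygen also remains untested here as a route to a stronger number.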